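Cytotoxicity notes: phenyl for methyl on the ring amine

This account rests on a few compounds, and the source may have more. Where it says the series, first, only, none or still open, it means among the compounds named here.

Measured in an ADME assay on MT4 cells (Homo sapiens) for cytotoxicity, read by MTT assay, with a stated time of 96 h; on this read-out lower numbers stand for higher toxicity in this test and higher numbers for lower toxicity in this test:
compound 1 `CN1CCN(CC(=O)Nc2ccc(-c3nc4cc(C(F)(F)F)ccc4n3C)cc2)CC1`: 22000 nM
compound 2 `CC(=O)Nc1ccc(-c2nc3ccccc3[nH]2)cc1`: 100000 nM
compound 3 `COc1ccc(-c2nc3cc(Cl)c(Cl)cc3[nH]2)cc1`: 1000 nM

Compound 1 stands second highest of the three numbers shown. Compound 2 gives a higher number, beyond the scatter, and compound 3 a lower number, further beyond the scatter. Within the data shown here, no pair of measured compounds differs in one place, so no measured step informs the next change. Compound 4 `Cn1c(-c2ccc(NC(=O)CN3CCN(c4ccccc4)CC3)cc2)nc2cc(C(F)(F)F)ccc21` differs from compound 1 in one place: phenyl in place of methyl on an amine nitrogen in a ring. With nothing directly comparable, a modest step toward a lower number is expected, and the step from compound 1 to compound 4 is estimated at a 2.2-fold lower number from compound 1 to compound 4 (0.34 log units; beyond the scatter), which may not clear the scatter. Compound 4 is expected at 10000 nM, between 3000 nM and 35000 nM.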

Compound 4, half-maximal cytotoxic concentration: 1500 nM
Compound 4: middle estimate off by 6.7-fold (0.82 log units), on the high side, outside the stated range (below it).
By their numbers in this assay, from the lowest: compounds 3 and 4 (each within the scatter of the next); then compound 1; then compound 2.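

In this assay the group on the amine nitrogen in the six-membered ring matters to the read-out: phenyl in place of methyl gives a 15-fold lower number from compound 1 to compound 4 (1.17 log units; beyond the scatter) as a large step. Among these compounds, this is the first one-place comparison, and it places the phenyl compound on the side of higher toxicity in this test. No measurement shown bears on the cause of this step.

Open, as far as these compounds go, is whether a benzyl group, a cyclohexyl ring or a pyridine ring on this nitrogen tracks with phenyl or with methyl. Also open, from the compounds shown here alone, is whether the step carries over to a core without the trifluoromethyl group.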